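Benzyl to 4-fluorobenzyl on compound 3

The source may report more compounds than this note shows. Statements on the series, on what has been measured and on what is new or still open speak of the compounds shown alone.

Of the compounds shown here, three have numbers so far in a functional assay on MDA-MB-231 cells (Homo sapiens) for inhibition, read by CCK-8 assay, with a stated time of 48 h; a lower number here means a stronger inhibitor of growth, a higher number a weaker inhibitor of growth. Compound 1 `Cc1ccccc1Nc1nc(Nc2ccccn2)ncc1Cl` gives 11200 nM, and compound 2 `Cc1ccccc1Nc1nc(Nc2ccc(N3CCCCC3)cc2)ncc1Cl` gives 19900 nM. Compound 3 `CN1CCN(c2ccc(Nc3ncc(Cl)c(NCc4ccccc4)n3)nc2)CC1` gives 24800 nM, the highest of the three numbers. That number lies within the scatter of the value for compound 2, while the gap to compound 1 lies beyond the scatter. All three compounds inhibit growth only weakly on these numbers, and no two of them differ in just one place. Among the compounds with values here, the series therefore offers no measured single-change step to carry over.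

The next compound, compound 4 `CN1CCN(c2ccc(Nc3ncc(Cl)c(NCc4ccc(F)cc4)n3)nc2)CC1`, keeps compound 3 intact except for the benzylamino group, which becomes (4-fluorobenzyl)amino: fluoro in place of hydrogen on an aromatic carbon. This places fluoro in place of hydrogen on an aromatic carbon, para to a large group. Within the data shown here, with no measured fluoro step to draw on, the expectation rests on the smallness of the change and on the value of compound 3 at 24800 nM. The expected step of a 1.2-fold lower number from compound 3 to compound 4 (0.09 log units; within the scatter) is none beyond the scatter in this assay, with no firm direction. For compound 4 the estimated value is 20000 nM, with an expected range from 9000 nM to 45000 nM.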

Compound 4, concentration for 50% growth inhibition: > 100000 nM
Compound 4: no number, only a limit; the forecaster's own chance of this, stated with the estimate: 5%; middle value at least 5.0-fold (0.69 log units) away from the limit.
By their numbers in this assay, from the lowest: compounds 1, 2 and 3 (each within the scatter of the next, the first and the last beyond it). At a limit, above all of these: compound 4.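

In this assay compound 4 gives > 100000 nM, which is a limit of the assay and not a number. This provides the series with its first single-change step, an at least 4.0-fold higher number from compound 3 to compound 4 (0.60 log units; beyond the scatter), and shows that the benzyl group of compound 3 does not tolerate every small change: one fluoro in place of hydrogen on an aromatic carbon, para to a large group, is enough to carry the growth inhibition of this scaffold beyond the scatter, towards weaker values. The reading is bounded by the top of the assay's range, so the step has a lower bound only and its true size cannot be read: the limit of > 100000 nM in this assay, at which 1 of the 4 values shown sits.

Going by these compounds, whether this weakening belongs to fluoro itself or to any group at this place stays open, and a comparison of compound 3 with its 4-chloro, 4-methoxy or 4-amino benzyl counterparts would separate the two. Also open, on these data alone, is whether the step carries over to the other compounds, since one pair cannot show whether fluoro at the same place on the 2-methylphenylamino group of compound 1 would act in the same direction.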